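The compounds below may be only part of what the source reports. "The series", "measured", "known", "first", "only" and "open" are said of these compounds alone.

Compound 1 `CSc1nnc(-c2cccc3ccccc23)n1C` gives, in a functional assay on the whole organism for antagonist activity, with Mus musculus as the target, in the maximal electroshock model (on this read-out lower numbers stand for an effect already at smaller amounts and higher numbers for an effect only at larger amounts of compound), a value of > 200 mg/kg, which is a limit of the assay and not a number. Compound 2 `Cn1c(-c2cccc3ccccc23)nnc1[S+](C)[O-]` gives in this assay a value of > 200 mg/kg, again a limit of the assay. Compound 3 `CSc1nnc(-c2ccccc2F)n1C` gives in this assay a value of > 200 mg/kg, likewise a limit and not a number.

Compound 2 is derived from compound 1 by the change (a group of 3 heavy atoms (1 carbon, 1 oxygen, 1 sulfur; no ring) in place of a group of 2 heavy atoms (1 carbon, 1 sulfur; no ring), on an aromatic carbon). Because both values are limits, the step that the two limits leave unreadable from compound 1 to compound 2 cannot be read, as the limit of > 200 mg/kg in this assay, at which 3 of the 3 values shown sit, records: every value in this set sits at that limit. How the core of compound 3 differs from the core of compound 1 is not broken down here.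

Compound 4 `Cn1c(-c2ccccc2F)nnc1[S+](C)[O-]` is not yet measured. It is derived from compound 3 by a group of 3 heavy atoms (1 carbon, 1 oxygen, 1 sulfur; no ring) in place of a group of 2 heavy atoms (1 carbon, 1 sulfur; no ring), on an aromatic carbon. Among the measured compounds shown here, this is the same kind of change as the one from compound 1 to compound 2, though not the same: the core of compound 3 differs from the core of compound 1, so the change is made on a different core.

For the measured compounds named here, for compound 4 in this assay the step that the limit leaves unreadable from compound 3 to compound 4 is what is expected, resting on (the limit of > 200 mg/kg in this assay, at which 3 of the 3 values shown sit), since the one measured instance of this kind of change left both compound 1 and compound 2 at the same limit. Compound 4 is therefore estimated at 300 mg/kg, with a likely range from 100 mg/kg to 800 mg/kg, and most probably the assay will again report a limit.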

Compound 4, dose for half-maximal effect: > 200 mg/kg
Compound 4: a limit, no number; the forecaster's own chance of this, stated with the estimate: 85%; the middle value is on the limit's open side.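

Neither compound 3 nor compound 4 yields a number in this assay, so the step between them cannot be read, because both values are limits of the assay: the limit of > 200 mg/kg in this assay, at which 4 of the 4 values shown sit.

The compounds shown leave open where the true values lie and whether replacing the methylsulfanyl group changes the read-out at all, on the core of compound 1 or on that of compound 3.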